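Hydroxyl for fluorine on the benzyl group of compound 1

A few compounds are considered here, and "the series" means these few. Any claim that something is new, unique, unknown or untested is made for them only; others in the source may bear on it.

Measured so far in a functional assay on G-361 cells (Homo sapiens) for antiproliferative activity, with a stated time of 72 h; a lower number here means a stronger inhibitor, a higher number a weaker inhibitor:
compound 1 `OC[C@H]1O[C@@H](n2cnc3c(NCc4cccc(F)c4)ncnc32)[C@H](O)[C@@H]1O` — > 166000 nM
compound 2 `OC[C@H]1O[C@@H](n2cnc3c(NCc4ccc(Cl)cc4)ncnc32)[C@H](O)[C@@H]1O` — > 166000 nM
compound 3 `OC[C@H]1O[C@@H](n2cnc3c(NCc4cccc(O)c4O)ncnc32)[C@H](O)[C@@H]1O` — 16900 nM

Compound 1 carries a 3-fluorophenyl group and gives only a limit of the assay, not a number, in this assay. Compound 2 also gives only a limit in this assay. Among the measured compounds shown here, compound 3 is the one measured compound with a number, and the step of an at least 9.8-fold lower number from compound 1 to compound 3 (0.99 log units; beyond the scatter) is beyond the scatter; likewise an at least 9.8-fold lower number from compound 2 to compound 3 (0.99 log units; beyond the scatter). The step that the two limits leave unreadable from compound 1 to compound 2 cannot be read, since both values sit at the limit of > 166000 nM in this assay, at which 2 of the 3 values shown sit.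

Compound 4 `Cc1cccc(CNc2ncnc3c2ncn3[C@@H]2O[C@H](CO)[C@@H](O)[C@H]2O)c1O` is not yet measured. It differs from compound 1 as 2-hydroxy-3-methylphenyl in place of 3-fluorophenyl on a saturated chain carbon bound to a nitrogen on an aromatic ring. For the measured compounds named here, the only step that bears on it is the one to compound 3, where a 2,3-dihydroxyphenyl enters and the number falls at least modestly. Compound 4 brings one hydroxyl together with a methyl rather than two hydroxyls, so a smaller fall than an at least 9.8-fold lower number from compound 1 to compound 3 (0.99 log units; beyond the scatter) is expected, with a real chance that only a limit is reported. Compound 4 is estimated at 45000 nM, within 12000 nM to 166000 nM, a step of an at least 3.6-fold lower number from compound 1 to compound 4 (0.56 log units; beyond the scatter).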

Compound 4, half-maximal inhibitory concentration: > 166000 nM
Compound 4 gave a limit, no number; the forecaster's own chance of this, stated with the estimate: 35%; middle value at least 3.6-fold (0.56 log units) from the limit.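

In this assay, methyl in place of hydroxy on an aromatic carbon gives an at least 9.8-fold higher number from compound 3 to compound 4 (0.99 log units; beyond the scatter), so the activity seen with compound 3 does not survive this single change. A lone hydroxyl on the benzyl group, as in the 2-hydroxy-3-methylbenzyl of compound 4, is therefore not enough to give a number, and compound 3 remains the only compound shown with one. The steps to compound 4 from compound 1 and from compound 2 cannot be read, since all three compounds give only a limit: the limit of > 166000 nM in this assay, at which 3 of the 4 values shown sit.

Going by these compounds, whether an amine or a methoxy group in place of that methyl would restore a number in this assay stays open. Any order among compound 1, compound 2 and compound 4 also stays open.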